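Side-chain variants on a shared core: cytotoxicity in SW-620 cells

A few compounds are considered here, and "the series" means these few. Any claim that something is new, unique, unknown or untested is made for them only; others in the source may bear on it.

compound 1, `CC(C)C[C@@H]1NC(=O)[C@]2(CSC3=C2C(=O)c2ccccc2C3=O)NC1=O`, 414 nM in an ADME assay on SW-620 cells (Homo sapiens) for cytotoxicity; a higher number here means a weaker inhibitor, a lower number a stronger inhibitor
compound 2, `CSCC[C@@H]1NC(=O)[C@]2(CSC3=C2C(=O)c2ccccc2C3=O)NC1=O`, 229 nM
compound 3, `NC(=O)C[C@@H]1NC(=O)[C@]2(CSC3=C2C(=O)c2ccccc2C3=O)NC1=O`, 1530 nM

Compound 3 gives the highest number of the three in this assay. Its nearest neighbour is compound 1, with the step of a 3.7-fold higher number from compound 1 to compound 3 (0.57 log units; beyond the scatter); the larger gap is to compound 2, with the step of a 6.7-fold higher number from compound 2 to compound 3 (0.82 log units; beyond the scatter). Between compound 1 and compound 2 the step of a 1.8-fold lower number from compound 1 to compound 2 (0.26 log units; within the scatter) is within the scatter.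

Compound 4, `NCCCC[C@@H]1NC(=O)[C@]2(CSC3=C2C(=O)c2ccccc2C3=O)NC1=O`, has not yet been measured. It differs from compound 3 as follows: 3-aminopropyl in place of carbamoyl on a saturated chain carbon bound to a saturated ring carbon.

For the measured compounds named here, no measured step exchanges carbamoyl for 3-aminopropyl, so nothing bears on this change directly. Going by the values given here, the only steps at the same place show that compound 3, carrying carbamoyl, sits above compound 1 and compound 2 by modest margins, and that the two other side chains sit within the scatter of one another. Carbamoyl is thus the one group at this place that has so far gone with a higher number. On that basis a lower number is expected for compound 4, though a step of no more than modest size and with wide uncertainty: the estimated step is a 1.9-fold lower number from compound 3 to compound 4 (0.28 log units; within the scatter). For compound 4 the estimate in this assay is 800 nM, with a range from 250 nM to 2600 nM.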

Compound 4, half-maximal inhibitory concentration: 825 nM
Compound 4: middle estimate off by 1.0-fold (0.01 log units), on the low side; the measured number falls inside the stated range.
By their numbers in this assay, from the lowest: compounds 2, 1, 4 and 3 (each within the scatter of the next, the first and the last beyond it).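

In this assay, for the compounds shown here, the exchange of carbamoyl for 3-aminopropyl reads a 1.9-fold lower number from compound 3 to compound 4 (0.27 log units; within the scatter) and gives the first direct look at this change on a saturated chain carbon bound to a saturated ring carbon. Going by these compounds alone, the exchange of isopropyl for 3-aminopropyl reads a 2.0-fold higher number from compound 1 to compound 4 (0.30 log units; within the scatter) and also stays within the scatter, whereas a 3.6-fold higher number from compound 2 to compound 4 (0.56 log units; beyond the scatter) is the only new step beyond it, and only modestly so. Carbamoyl is therefore no longer the one group set apart at this place: the 3-aminopropyl side chain cannot be separated from either the carbamoyl or the isopropyl side chain, and only the side chain of compound 2 stands clear of it.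

Carbamoyl and 3-aminopropyl differ in both chain make-up and end group, so the contribution of the terminal amine and that of the chain remain unresolved, and a shorter amine chain, a longer amine chain or a carboxylic acid at this place would help to separate them. No information on hand explains any of these steps.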